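Replacing a Benzamide with a Dichlorophenyl Urea

The source may report more compounds than this note shows. Statements on the series, on what has been measured and on what is new or still open speak of the compounds shown alone.

Compound 1 `COc1cc(-c2nn(-c3cccc(NC(=O)c4ccc(Cl)c(C(F)(F)F)c4)c3)cc2-c2ccncc2)ccc1Cl` — > 32500 nM, a limit of the assay
Compound 2 `COc1cc(-c2nn(-c3cccc(NC(=O)c4ccccc4)c3)cc2-c2ccncc2)ccc1Cl` — > 100000 nM, a limit of the assay

Both measured compounds share one core and differ only in the group on the amide carbonyl carbon. In a functional assay on MOLT-4 cells (Homo sapiens) for inhibition, read by sulforhodamine B assay, with a stated time of 48 h (a lower number here means a stronger inhibitor of growth, a higher number a weaker inhibitor of growth), compound 1 gives > 32500 nM, which is a limit rather than a number. In this assay compound 2 gives > 100000 nM, again a limit and not a measured value. The step that the two limits leave unreadable from compound 1 to compound 2 therefore has no readable size; it is hemmed in only by the limit of > 32500 nM in this assay, at which 1 of the 2 values shown sits, on one side and the limit of > 100000 nM in this assay, at which 1 of the 2 values shown sits, on the other. Compound 2 thus stands at the weakest position the numbers allow: nothing shows it inhibiting growth at any concentration tested.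

Compound 3 `COc1cc(-c2nn(-c3cccc(NC(=O)Nc4ccc(Cl)c(Cl)c4)c3)cc2-c2ccncc2)ccc1Cl` differs from compound 2 by (3,4-dichlorophenyl)amino in place of phenyl on a carbonyl carbon. Within the data shown here, the one measured step at this position, a step that the two limits leave unreadable from compound 1 to compound 2, bears on the change but is unreadable, so it offers neither direction nor size. Compound 3 is therefore expected to stay weak, with an estimated value of 60000 nM and a range from 10000 nM to 200000 nM. This corresponds to an expected step of an at least 1.6-fold lower number from compound 2 to compound 3 (0.22 log units; that floor lies within the scatter), most likely ending again at a limit.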

Compound 3, concentration for total growth inhibition: 4480 nM
Beside the measured number, compound 3's estimate is 13-fold (1.13 log units) above it; the measured number lies below the stated range.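

Among these compounds, for the first time, a compound gives a measured number rather than a limit, so the change at this position can be sized. In this assay, putting (3,4-dichlorophenyl)amino on the carbonyl carbon in place of phenyl gives an at least 22-fold lower number from compound 2 to compound 3 (1.34 log units; beyond the scatter), and the same group in place of 4-chloro-3-(trifluoromethyl)phenyl gives an at least 7.2-fold lower number from compound 1 to compound 3 (0.86 log units; beyond the scatter), which shows that a halogen-bearing ring on the carbonyl carbon does not by itself bring a measured value, whereas this urea-type link with its dichlorophenyl ring does. The true size of the first step remains unknown because its starting compound sits at a limit: the limit of > 100000 nM in this assay, at which 1 of the 3 values shown sits.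

The amino nitrogen and the two chlorine atoms enter together, so the compounds shown cannot separate the contribution of one from that of the other. A plain phenylamino group on the same carbonyl carbon would divide the two, and a methylene in place of the amino nitrogen, keeping the 3,4-dichlorophenyl ring, would test whether that nitrogen is needed at all.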